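Swapping methoxycarbonyl for methoxy in a cytotoxicity test

The compounds below may be only part of what the source reports. "The series", "measured", "known", "first", "only" and "open" are said of these compounds alone.

Compound 1 `COc1ccc(NC(=O)Nc2cc(C)nc3ccccc23)cc1OC`: > 25000 nM
Compound 2 `COC(=O)c1cccc(NC(=O)Nc2cc(C)nc3ccccc23)c1`: 26000 nM

Both compounds were tested in an ADME assay on HEK293 cells (Homo sapiens) for cytotoxicity, with a stated time of 72 h; on this read-out lower numbers stand for an effect already at smaller amounts and higher numbers for an effect only at larger amounts of compound. Compound 1 gives only a limit, > 25000 nM, and not a number. For the measured compounds named here, compound 2, at 26000 nM, holds the only actual number so far, so the two cannot yet be ranked.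

Compound 3 `COc1cccc(NC(=O)Nc2cc(C)nc3ccccc23)c1` has methoxy in place of the methoxycarbonyl of compound 2, on an aromatic carbon, meta to a large group: methoxy in place of methoxycarbonyl on an aromatic carbon. Going by the values given here, no measured step between two compounds is available as a guide, so no change beyond the scatter is expected. Compound 1 also carries methoxy, and its result is the limit > 25000 nM. The estimated step of a 1.2-fold lower number from compound 2 to compound 3 (0.07 log units; within the scatter) therefore stays small. For compound 3 the estimate is 22000 nM, with an expected range of 10000 nM to 40000 nM.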

Compound 3, half-maximal effective concentration: > 25000 nM
Compound 3 gave a limit, no number; the forecaster's own chance of this, stated with the estimate: 45%; middle value at least 1.1-fold (0.05 log units) away from the limit.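

No step can be read from compound 2 to compound 3 or from compound 1 to compound 3, because the comparison runs into a limit and not a number: the limit of > 25000 nM in this assay, at which 2 of the 3 values shown sit. The compounds shown leave open whether methoxy and methoxycarbonyl differ at all in this assay.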